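The source may hold more compounds than are shown below. What is called first, only, known or untested is meant among the compounds shown, and "the series" means these compounds.

Compound 1 `Cc1cccc2cc(/C=C3\SC(=S)NC3=O)c(Cl)nc12` was tested in a toxicity assay on HUVEC cells (Homo sapiens) for cytotoxicity, read by MTT assay, with a stated time of 48 h; on this read-out lower numbers stand for stronger inhibition of growth and higher numbers for weaker inhibition of growth. In this assay compound 1 gives only a limit, > 100 ug/mL. Compound 2 `O=C1NC(=S)S/C1=C\c1cc2cc(F)ccc2nc1Cl` in this assay likewise gives a limit, > 100 ug/mL. The two values shown sit at the limit of > 100 ug/mL in this assay, at which 2 of the 2 values shown sit, so compound 1 stands at the limit with no number of its own. Compound 3 `Cc1cccc2cc(/C=C3\SC(=S)N(CC(=O)O)C3=O)c(Cl)nc12` differs from compound 1 by carboxymethyl in place of hydrogen on an amide-type nitrogen in a ring. Going by the values given here, no measured step covers such a change here. The step from compound 1 to compound 3 is expected to stay within the scatter, as a number no higher from compound 1 to compound 3 (the limit leaves the size open). Compound 3 is estimated at 100 ug/mL, between 50 ug/mL and 200 ug/mL.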

Compound 3, concentration for 50% growth inhibition: > 100 ug/mL
Compound 3 was reported as a limit (the forecaster's own chance of this, stated with the estimate: 80%); the middle value lies on the limit itself.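

No step from compound 1 to compound 3 can be read in this assay, because both compounds give only limits: the limit of > 100 ug/mL in this assay, at which 3 of the 3 values shown sit.

The compounds shown leave open whether carboxymethyl in place of hydrogen on the amide-type nitrogen alters growth inhibition at all.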